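Lipophilicity notes: benzyl amide variation on the shared core

This account rests on a few compounds, and the source may have more. Where it says the series, first, only, none or still open, it means among the compounds named here.

Compound 2 `COc1ccc(CNC(=O)c2nc(-c3ccc(F)cc3)n(CC[C@@H](O)C[C@@H](O)CC(=O)O)c2C2CC2)cc1` stands lowest of the three compounds measured in a physicochemical assay for lipophilicity, using the shake flask method, at pH 7.4 (a higher number here means a more lipophilic compound, a lower number a more polar compound), where compound 2 gives 0.02. Compound 1 `Cc1ccc(CNC(=O)c2nc(-c3ccc(F)cc3)n(CC[C@@H](O)C[C@@H](O)CC(=O)O)c2C2CC2)cc1` gives 0.45, and compound 3 `CC(C)c1c(C(=O)NCc2ccccc2)nc(-c2ccc(F)cc2)n1CC[C@@H](O)C[C@@H](O)CC(=O)O` gives 0.64; both sit beyond the scatter above compound 2. Compound 4 `O=C(O)C[C@H](O)C[C@H](O)CCn1c(-c2ccc(F)cc2)nc(C(=O)NCc2ccccc2F)c1C1CC1` differs from compound 2 in one place: 2-fluorophenyl in place of 4-methoxyphenyl on a saturated chain carbon bound to an amide-type nitrogen. For the measured compounds named here, the only measured step bearing on this position is a number 0.43 log units lower from compound 1 to compound 2 (beyond the scatter); no measured step covers the 4-methoxybenzyl to 2-fluorobenzyl exchange itself. The step from compound 2 to compound 4 in this assay is therefore expected to be a modest rise, a number 0.33 log units higher from compound 2 to compound 4 (beyond the scatter), comparable to reversing the earlier step. Compound 4 is estimated at 0.35, within 0.05 to 0.65.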

Compound 4, distribution coefficient: 0.08
Estimate against measurement, compound 4: 0.27 log units above, within the range that was stated.
By their numbers in this assay, from the lowest: compounds 2 and 4 (each within the scatter of the next); then compounds 1 and 3 (each within the scatter of the next).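

Among the benzyl amides on the cyclopropyl-bearing core, the 4-methoxybenzyl to 2-fluorobenzyl exchange gives a number 0.06 log units higher from compound 2 to compound 4 (within the scatter) in this assay, so the two groups cannot be told apart at this position. The exchange of 4-methylphenyl for 2-fluorophenyl gives a number 0.37 log units lower from compound 1 to compound 4 (beyond the scatter) and is close in size to the earlier methyl to methoxy step, so the gap from compound 1 is not confined to methoxy. No available evidence accounts for this result.

Still open, going by these compounds, is how an amine or a carboxylic acid on the benzyl group would read at this position. Also open, on these data alone, is whether 4-fluorobenzyl would sit with 2-fluorobenzyl.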